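This account rests on a few compounds, and the source may have more. Where it says the series, first, only, none or still open, it means among the compounds named here.

Working notes on the series. Of the compounds shown here, three with a shared core have been measured in a functional assay on the whole organism (B cells) with Mus musculus as the target; a lower number here means a smaller maximal response, a higher number a larger maximal response. Compound 1 `CCCn1c(=O)n(C2OC(COP(=O)(O)O)[C@@H](O)[C@H]2O)c2nc(N)nc(O)c21` gives 76%. Compound 2 `C=CCn1c(=O)n(C2CCC(CO)C2)c2nc(N)nc(O)c21`, which differs from the other two at several places, gives 26%. Compound 3 `CN(C)CCCn1c(=O)n(C2OC(CO)[C@@H](O)[C@H]2O)c2nc(N)nc(O)c21` gives 83%, the highest of the three numbers; its gap to compound 1 lies within the scatter, whereas its gap to compound 2 lies beyond it.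

Compound 4 `Cn1c(=O)n(C2OC(CO)[C@@H](O)[C@H]2O)c2nc(N)nc(O)c21` has not yet been measured. It differs from compound 3 by hydrogen in place of 2-(dimethylamino)ethyl on a saturated chain carbon bound to an aromatic nitrogen. Going by the values given here, no measured pair shows this change on its own, so the size of the step cannot be read from the data. Compounds 1 and 3 both give a large response, but nothing measured tells what a methyl on the aromatic nitrogen does. A modest loss is expected: the step from compound 3 to compound 4 is estimated at a number 23 percentage points lower from compound 3 to compound 4 (beyond the scatter). Compound 4 is expected to give 60%, within a range from 30% to 90%.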

Compound 4, largest response reached (reported as maximal response), in percent of the reference or control that the assay uses: 99%
Compound 4: the middle estimate sits 39 percentage points below what was measured; the whole stated range lies below it.
By their numbers in this assay, from the lowest: compound 2; then compounds 1 and 3 (each within the scatter of the next); then compound 4.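

In this assay, going by these compounds alone, hydrogen in place of 2-(dimethylamino)ethyl on a saturated chain carbon bound to an aromatic nitrogen gives a number 16 percentage points higher from compound 3 to compound 4 (beyond the scatter) in the first pair to show this change on its own. The dimethylamino-bearing chain is therefore not required for a large response in this pair, and the plain methyl of compound 4 outperforms the 3-(dimethylamino)propyl of compound 3. Nothing available accounts for the direction of this step.

One pair cannot separate the length of the chain from the presence of its terminal amine, and compounds 1 and 2 differ from compound 4 at several places, so they add no reading of this position. An ethyl or butyl chain, or a chain ending in a carboxylic acid, would be needed to tell these apart.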